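The source may report more compounds than this note shows. Statements on the series, on what has been measured and on what is new or still open speak of the compounds shown alone.

Within the data shown here, compound 2 `N#Cc1cccc(-c2ccc(Cl)c(C(=O)NCC3(O)CCCCCC3)c2)n1` gives 232 nM in a functional assay on HEK293 cells for antagonist activity at P2X purinoceptor 7 (Homo sapiens) (on this read-out higher numbers stand for weaker inhibition and lower numbers for stronger inhibition), and stands as the higher of the two numbers measured so far; its only neighbour is compound 1 `Cc1cnc(-c2ccc(Cl)c(C(=O)NCC3(O)CCCCCC3)c2)cn1`, which in this assay gives 22 nM. Among the measured compounds shown here, the one measured step in the set is an 11-fold higher number from compound 1 to compound 2 (1.02 log units; beyond the scatter), an exchange of one heteroaryl group for another at the same aromatic carbon. Compound 3 `Cc1cnc(-c2ccc(Cl)c(C(=O)NCC3(O)CCCCCC3)c2)nc1` is not yet measured. It differs from compound 2 in one place: 5-methylpyrimidin-2-yl in place of 6-cyanopyridin-2-yl on an aromatic carbon. The entering group is a close relative of the group carried by compound 1, a methyl-bearing six-membered ring with two hetero atoms, whereas the leaving group is the one whose introduction gave the large step. For the measured compounds named here, no step between compound 1 and compound 3 is known, so the only step that bears on the change is an 11-fold higher number from compound 1 to compound 2 (1.02 log units; beyond the scatter), read in reverse. The number is therefore expected to fall by a step estimated at a 7.7-fold lower number from compound 2 to compound 3 (0.89 log units; beyond the scatter). For compound 3 the expected value in this assay is 30 nM, within a range from 10 nM to 100 nM.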

Compound 3, half-maximal inhibitory concentration: 8 nM
Beside the measured number, compound 3's estimate is 3.8-fold (0.57 log units) above it; the measured number lies below the stated range.
By their numbers in this assay, from the lowest: compound 3; then compound 1; then compound 2.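

Read in this assay, the position on the aromatic carbon para to the chloro group is shown to respond to more than a single heteroaryl exchange: a 29-fold lower number from compound 2 to compound 3 (1.46 log units; beyond the scatter), so the loss seen with 6-cyanopyridin-2-yl is not a ceiling for this place, and a ring carrying 2 hetero atoms and a methyl recovers it in full. The two methyl-bearing rings are also told apart, with a 2.8-fold lower number from compound 1 to compound 3 (0.44 log units; beyond the scatter), which shows that the arrangement of the hetero atoms within the ring matters here, and not only the presence of the methyl. No measurement at hand accounts for either step.

Going by these compounds, compound 2 differs from compound 3 in both the ring and its substituent, so it remains open whether the nitrile or the pyridine ring carries the weaker inhibition; a methyl in place of the nitrile on the pyridine ring would separate the two. Also open, on these data alone, is how far the methyl on the pyrimidine ring can be exchanged, for instance for a methoxy group or an amine.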